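Ether Linker Returns with a Pyrazole Tail

The compounds below may be only part of what the source reports. "The series", "measured", "known", "first", "only" and "open" are said of these compounds alone.

Measured compounds and their numbers in a functional assay on HEK293 cells for agonist activity at G-protein coupled receptor 39 (Homo sapiens), read by scintillation proximity assay and inositol phosphate accumulation, with a stated time of 75 min; on this read-out lower numbers stand for an effect already at smaller amounts and higher numbers for an effect only at larger amounts of compound:
- Compound 1 `Cc1nn(-c2ncnc3nc[nH]c23)c2c1C(c1ccc(OC(C)C)cc1)CC(=O)N2` gives 2700 nM
- Compound 2 `Cc1nn(-c2ncnc3nc[nH]c23)c2c1C(OCc1ccccc1Cl)CC(=O)N2` gives 47 nM
- Compound 3 `Cc1nn(-c2ncnc3nc[nH]c23)c2c1C(NC(=O)Cc1cccs1)CC(=O)N2` gives 244 nM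

Compound 3 sits second highest of the three numbers: its nearest neighbour is compound 2 with a lower number, its furthest is compound 1 with a higher number, and both gaps lie beyond the usual scatter. All three compounds share the same core and differ only in the group attached to one saturated ring carbon.

Compound 4 `Cc1nn(-c2ncnc3nc[nH]c23)c2c1C(OCCn1cccn1)CC(=O)N2` has not yet been measured. It differs from compound 3 in one place: 2-(1H-pyrazol-1-yl)ethoxy in place of (((thiophen-2-yl)methyl)carbonyl)amino on a saturated ring carbon. The group that leaves is joined through an amide; the group that enters is joined through an oxygen, as in compound 2.

The step that bears most directly is the one between the two linker types already seen: a 5.2-fold higher number from compound 2 to compound 3 (0.72 log units; beyond the scatter). Going back from the amide to an oxygen linker therefore points toward a lower number, though the ring on the chain is now a pyrazole rather than a substituted benzyl, so the full gain of compound 2 cannot be assumed. A modest drop is expected, a 2.4-fold lower number from compound 3 to compound 4 (0.39 log units; beyond the scatter). Compound 4 is estimated at 100 nM, with a range from 30 nM to 400 nM.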

Compound 4, half-maximal effective concentration: 2270 nM
The estimate for compound 4 lay 23-fold (1.36 log units) below the measured number; measured number above the stated range.
By their numbers in this assay, from the lowest: compound 2; then compound 3; then compounds 4 and 1 (each within the scatter of the next).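

In this assay, an oxygen linker on this saturated ring carbon does not by itself give a low number: with the oxygen kept and only the group it carries changed, there is a 48-fold higher number from compound 2 to compound 4 (1.68 log units; beyond the scatter) and that change is (1H-pyrazol-1-yl)methyl in place of 2-chlorophenyl. Returning from the amide of compound 3 to an oxygen linker also raises the number here, with a 9.3-fold higher number from compound 3 to compound 4 (0.97 log units; beyond the scatter) in a direction opposite to what the pair of compound 2 and compound 3 alone might suggest, so the linker cannot be read apart from what it carries. The 2-(1H-pyrazol-1-yl)ethoxy group also cannot be told apart from the very different 4-isopropoxyphenyl group, with a 1.2-fold lower number from compound 1 to compound 4 (0.08 log units; within the scatter) as the step between them.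

Still open, going by these compounds, is whether the pyrazole ring or the two-carbon chain matters more, a question that a 2-phenylethoxy group or a plain benzyloxy group on the same carbon could help to separate. No measurement offered here accounts for the size of these steps.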